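The source may report more compounds than this note shows. Statements on the series, on what has been measured and on what is new or still open speak of the compounds shown alone.

Working notes on the series, with all readings taken in a functional assay on HepG2 cells (Homo sapiens) for antiproliferative activity, read by MTT assay, with a stated time of 48 h (on this read-out lower numbers stand for stronger inhibition and higher numbers for weaker inhibition), throughout. Compound 1 (`COc1ccc(-c2c(Nc3ccc(F)cc3)c3ccc(OC)cc3oc2=O)cc1`) reports > 100000 nM as a limit of the assay and not a number. Among the compounds with values here, compound 2 (`COc1ccc(Nc2c(C(=O)C(F)(F)F)c(=O)oc3cc(OC)ccc23)cc1`) gives 38400 nM as the only true number so far, so its standing rests on this one measured point. Compound 3 (`COc1ccc2c(Nc3ccc(F)cc3)c(C(=O)C(F)(F)F)c(=O)oc2c1`) is still unmeasured. Its difference from compound 2 (fluoro in place of methoxy on an aromatic carbon) is fluoro in place of methoxy on an aromatic carbon, para to a large group, so that (4-methoxyphenyl)amino becomes (4-fluorophenyl)amino.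

Within the data shown here, no measured step shows what this exchange does in this assay so the size of any shift cannot yet be read from the data. The working expectation stays close to compound 2 at 38400 nM with no step beyond the usual scatter in either direction. The estimated change, a 1.2-fold lower number from compound 2 to compound 3 (0.08 log units; within the scatter) is expected to stay inside that scatter. The range is kept wide, as a single number is the only anchor. For compound 3 the expected value is 32000 nM with an estimated range of 10000 nM to 90000 nM for the measurement.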

Compound 3, half-maximal inhibitory concentration: 8260 nM
For compound 3 the middle estimate is 3.9-fold (0.59 log units) above the measured one; the measured number lies below the stated range.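

In this assay, the aromatic carbon para to a large group now has a measured response: with fluoro in place of methoxy, so that (4-methoxyphenyl)amino becomes (4-fluorophenyl)amino, the series shows a 4.6-fold lower number from compound 2 to compound 3 (0.67 log units; beyond the scatter). Within the data shown here, the exchange of (trifluoromethyl)carbonyl in place of 4-methoxyphenyl on an aromatic carbon adds a second step, an at least 12-fold lower number from compound 1 to compound 3 (1.08 log units; beyond the scatter), which gives the first reading on that other place in the shared core. Compound 1 stands at a limit of the assay and not at a number, so this second step holds only as a bound and its true size stays unknown: the limit of > 100000 nM in this assay, at which 1 of the 3 values shown sits.

The compounds shown carry only methoxy and fluoro at the para carbon, so they cannot tell whether the step follows from losing methoxy or from gaining fluoro; a plain hydrogen, a chloro or a dimethylamino group there would separate the two readings. Going by these compounds, it also stays open whether a nitrile or a carboxylic acid could stand in for (trifluoromethyl)carbonyl, and whether the step from methoxy to fluoro would keep its size with such a group in that place.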